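Dithiocarbamate benzamides: swapping the piperazine aryl group

The source may hold more compounds than are shown below. What is called first, only, known or untested is meant among the compounds shown, and "the series" means these compounds.

Of the compounds shown here, two have numbers so far. Compound 1 `Nc1ccccc1NC(=O)c1ccc(CSC(=S)N2CCN(c3ccc(F)cc3)CC2)cc1` gives 76.3% in a functional assay on A-375 cells (Homo sapiens) for antiproliferative activity, read by CCK-8 assay, with a stated time of 72 h, tested at 8 uM; a higher number here means a stronger effect of the compound at the concentration tested, a lower number a weaker effect. For the measured compounds named here, compound 2 `N#Cc1ccc(N2CCN(C(=S)SCc3ccc(C(=O)Nc4ccccc4N)cc3)CC2)cc1` gives 62.9% in this assay, the lower of the two numbers; the only measured step, a number 13.4 percentage points lower from compound 1 to compound 2 (beyond the scatter), places compound 2 beyond the scatter below compound 1.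

The next compound, compound 3 `Nc1ccccc1NC(=O)c1ccc(CSC(=S)N2CCN(Cc3cccnc3)CC2)cc1`, is not yet measured. It differs from compound 2 in one place: (pyridin-3-yl)methyl in place of 4-cyanophenyl on an amine nitrogen in a ring. The substituent on the ring nitrogen is thus no longer an aromatic ring bound directly to that nitrogen but a (pyridin-3-yl)methyl group.

Going by the values given here, no measured step covers a change of this kind. Among the compounds with values here, the single step, from fluoro to cyano, was modest and changed only the substituent on the 4-cyanophenyl ring; it gives no guide to replacing that whole ring. The expectation therefore leans on compound 2 alone, with wide uncertainty in either direction, and no clear step beyond the scatter is predicted. For compound 3 the estimated value in this assay is 63%, within 43% to 83%, which means an expected step of a number 0.1 percentage points higher from compound 2 to compound 3 (within the scatter).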

Compound 3, a percentage reported as inhibition, at one concentration (the size of the read-out at that concentration, not a potency): 89.2%
Compound 3: middle estimate off by 26.2 percentage points, on the low side; the measured number lies above the stated range.
By their numbers in this assay, from the lowest: compound 2; then compound 1; then compound 3.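

In this assay, the amine nitrogen in a ring accepts more than a substituted phenyl group bound directly to it: (pyridin-3-yl)methyl in place of 4-cyanophenyl gives a number 26.3 percentage points higher from compound 2 to compound 3 (beyond the scatter), and the same group in place of 4-fluorophenyl gives a number 12.9 percentage points higher from compound 1 to compound 3 (beyond the scatter). The earlier step changed only a substituent on the phenyl ring, whereas these steps replace the whole group and place compound 3 beyond the scatter above both compounds carrying a directly bound phenyl ring. Nothing available explains this rise, and each step changes both the aromatic ring and its attachment to the amine nitrogen, so the two changes cannot be separated.

The compounds shown leave open whether the gain follows the pyridine ring or the methyl attachment, a question that benzyl and directly bound pyridin-3-yl groups on the same nitrogen would address. They also leave open whether (pyridin-2-yl)methyl or (pyridin-4-yl)methyl would keep the higher read-out, and, with one concentration on one cell line, how the compounds rank by potency.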